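The source may report more compounds than this note shows. Statements on the series, on what has been measured and on what is new or still open speak of the compounds shown alone.

Measured so far:

Compound 1 `CCOc1ccc(NC2=CC(=O)c3c(nc4n3[C@H]3OC[C@@H](O)[C@H]3OC4)C2=O)cc1`: in a functional assay on ECa-109 cells for inhibition, with ECa-109 cell line (Homo sapiens) as the target, read by sulforhodamine B assay (on this read-out lower numbers stand for stronger inhibition and higher numbers for weaker inhibition), compound 1 gives > 4000 nM, which is a limit of the assay.

Compound 2 `COc1ccccc1NC1=CC(=O)c2c(nc3n2[C@H]2OC[C@@H](O)[C@H]2OC3)C1=O`: in this assay compound 2 gives > 4000 nM, also a limit.

Compound 3 `O=C1C(NC2CCCCC2)=CC(=O)c2c1nc1n2[C@H]2OC[C@@H](O)[C@H]2OC1`: in this assay compound 3 gives > 16000 nM, again a limit.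

Compound 3 therefore stands at a limit, and the two further values are limits as well, as the limit of > 4000 nM in this assay, at which 2 of the 3 values shown sit, and the limit of > 16000 nM in this assay, at which 1 of the 3 values shown sits, show. Compound 4 `O=C1C(Nc2ccccc2F)=CC(=O)c2c1nc1n2[C@H]2OC[C@@H](O)[C@H]2OC1` arises from compound 3 by 2-fluorophenyl in place of cyclohexyl on an amine nitrogen. The measured steps that touch the same amine nitrogen, a step that the two limits leave unreadable from compound 1 to compound 3 and a step that the two limits leave unreadable from compound 2 to compound 3, are both left unreadable by the limits. With no readable step, no direction beyond the scatter can be expected. The value of compound 4 is estimated at 9000 nM, with a range from 3000 nM to 40000 nM. This estimate means an expected step of an at least 1.7-fold lower number from compound 3 to compound 4 (0.24 log units; that floor lies within the scatter), and a limit rather than a number is the likely report.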

Compound 4, half-maximal inhibitory concentration: 2660 nM
Compound 4: middle estimate off by 3.4-fold (0.53 log units), on the high side; the measured number lies below the stated range.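

For the compounds shown here, compound 4 is the first compound here with a measured number rather than a limit, which shows that the group on this amine nitrogen can change the read-out: an at least 6.0-fold lower number from compound 3 to compound 4 (0.77 log units; beyond the scatter). Against the two alkoxy-bearing aromatic compounds, the change is less clear: fluoro in place of methoxy gives an at least 1.5-fold lower number from compound 2 to compound 4 (0.17 log units; that floor lies within the scatter), and 2-fluorophenyl in place of 4-ethoxyphenyl gives an at least 1.5-fold lower number from compound 1 to compound 4 (0.17 log units; that floor lies within the scatter). Both of these floors lie within the scatter, so neither comparison establishes a real gain.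

Going by these compounds, it remains open whether the fluorine matters or an unsubstituted phenyl would do as well. Chloro on the ring, or a longer chain on the nitrogen, is also untested among the compounds shown.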